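Methyl in Place of Hydrogen on a Shared Core

The source may report more compounds than this note shows. Statements on the series, on what has been measured and on what is new or still open speak of the compounds shown alone.

Measured in a functional assay on SW1573 cells (Homo sapiens) for inhibition, read by sulforhodamine B assay, with a stated time of 48 h; a lower number here means a stronger inhibitor of growth, a higher number a weaker inhibitor of growth:
Compound 1 `COC(=O)[C@@]1(C)CCC=C2[C@@H]1CC[C@@H](C)[C@]2(C)Cc1c[nH]c2ccc(Cl)cc12` gives 11000 nM.
Compound 2 `COC(=O)[C@@]1(C)CCC=C2[C@@H]1CC[C@@H](C)[C@]2(C)Cc1c(C)[nH]c2ccccc12` gives 14000 nM.
Compound 3 `COC(=O)[C@@]1(C)CCC=C2[C@@H]1CC[C@@H](C)[C@]2(C)Cc1c(C)[nH]c2ccc(Cl)cc12` gives 14000 nM.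

Compound 4 `COC(=O)[C@@]1(C)CCC=C2[C@@H]1CC[C@@H](C)[C@]2(C)Cc1c(C)[nH]c2c(C)cccc12` is not yet measured. It differs from compound 2 by methyl in place of hydrogen on an aromatic carbon. The same kind of change, (methyl in place of hydrogen on an aromatic carbon), was made between measured compounds and gave a 1.3-fold higher number from compound 1 to compound 3 (0.10 log units; within the scatter). The places differ: in compound 3 the methyl enters on a five-membered aromatic ring with 1 nitrogen, next to the ring nitrogen, while in compound 4 it enters on a six-membered aromatic ring of carbon only, ortho to a fused ring. The difference between the cores of compound 1 and compound 2 is not broken down here; the step of no change at the digits printed from compound 2 to compound 3 (within the scatter) also stays within the scatter. Because the earlier methyl step a 1.3-fold higher number from compound 1 to compound 3 (0.10 log units; within the scatter) stayed within the scatter, compound 4 is expected to show no change at the digits printed from compound 2 to compound 4 (within the scatter). For compound 4 the estimate is 14000 nM, from 7000 nM to 28000 nM.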

Compound 4, concentration for 50% growth inhibition: 15000 nM
Compound 4: the middle estimate sits 1.1-fold (0.03 log units) below what was measured; the measured number falls inside the stated range.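

In this assay, methyl in place of hydrogen on an aromatic carbon of the six-membered aromatic ring gave a 1.1-fold higher number from compound 2 to compound 4 (0.03 log units; within the scatter). Set beside the earlier methyl step, the change reads alike on the two cores: the same change on two cores in this assay, a 1.3-fold higher number (0.10 log units; within the scatter) from compound 1 to compound 3 and a 1.1-fold higher number (0.03 log units; within the scatter) from compound 2 to compound 4, 1.2-fold (0.07 log units) apart, within the scatter of two such steps. This shows that in these two cases the methyl left the number within the scatter, but it does not show that the result would carry to other cores, and as the two methyl groups enter on different rings, the pair cannot separate the role of the core from that of the place.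

The compounds shown leave open whether another group at that place, such as an amine or a longer chain, would give a step beyond the scatter. They also leave open what a carboxylic acid in place of the methyl ester would do.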